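This account rests on a few compounds, and the source may have more. Where it says the series, first, only, none or still open, it means among the compounds named here.

Measured so far:
compound 1 `O=C(O)c1cn(Cc2ccc(Br)cc2)c2ccccc2c1=O` — 25.4%
compound 2 `O=C(NO)c1cn(Cc2ccc(Br)cc2)c2ccccc2c1=O` — 27.6%
compound 3 `COc1cc(Cn2cc(C(=O)NO)c(=O)c3ccccc32)cc(OC)c1` — 41.3%

All three values come from a functional assay, tested at 100 uM; a higher number here means a stronger effect of the compound at the concentration tested, a lower number a weaker effect. Compound 2 holds the second highest of the three numbers; its nearest neighbour is compound 1, whose 25.4% lies within the scatter of it, and the furthest is compound 3, whose 41.3% lies beyond the scatter above it. Among the measured compounds shown here, the only measured step, a number 2.2 percentage points higher from compound 1 to compound 2 (within the scatter), changes the carbonyl-bound group and says nothing about the ring on the chain carbon.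

Compound 4 `O=C(NO)c1cn(Cc2ccc(O)c(O)c2)c2ccccc2c1=O` differs from compound 2 by 3,4-dihydroxyphenyl in place of 4-bromophenyl on a saturated chain carbon bound to an aromatic nitrogen. For the measured compounds named here, no measured step bears on this exchange directly. Compound 2 and compound 3 carry different groups on the same chain carbon, and their two values show the one without bromine as the higher, which is the only hint available. The expected step in this assay is therefore a modest rise, a number 7.4 percentage points higher from compound 2 to compound 4 (within the scatter), though a result inside the scatter would not surprise. Compound 4 is estimated at 35%, with a range from 20% to 50%.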

Compound 4, a percentage reported as activity, at one concentration (the size of the read-out at that concentration, not a potency): 88.1%
Estimate against measurement, compound 4: 53.1 percentage points below; the measured number lies above the stated range.
By their numbers in this assay, from the lowest: compounds 1 and 2 (each within the scatter of the next); then compound 3; then compound 4.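

Notes on the chain-carbon position: in this assay, 3,4-dihydroxyphenyl in place of 4-bromophenyl on a saturated chain carbon bound to an aromatic nitrogen gives a number 60.5 percentage points higher from compound 2 to compound 4 (beyond the scatter). Among the compounds shown here, this is the first measured one-place exchange at this position, and it shows that the read-out can move far here, whereas the one measured change at the carbonyl-bound group, a number 2.2 percentage points higher from compound 1 to compound 2 (within the scatter), stays within the scatter. Nothing available explains the size of this step.

It remains open whether both hydroxy groups are needed, since a phenyl ring carrying a single hydroxy group, or amino groups in their place, is not among the compounds shown. Also open, on these data alone, is whether 3,4-dihydroxyphenyl gives a similar read-out with the carboxylic acid of compound 1 on the carbonyl carbon.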